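The source may report more compounds than this note shows. Statements on the series, on what has been measured and on what is new or still open speak of the compounds shown alone.

Compound 1, `O=C1CCCN1c1cnc(NCc2c(F)ccc3c2CCO3)n2cnnc12`, stands highest among the three measured compounds in a physicochemical assay for solubility, read by LC-MS, in phosphate buffer, with a stated time of 24 h, at pH 7.4 (on this read-out higher numbers stand for higher solubility and lower numbers for lower solubility), where compound 1 gives 640000 nM. The two other measured compounds carry different cores and cannot be joined to compound 1 by a single change. Compound 2, `Cc1ncccc1-c1cnc(NCc2c(F)ccc3c2CCO3)c2nn(CC#N)c(=O)n12`, gives 4000 nM in this assay, a number far below that of compound 1 and beyond the scatter. Compound 3, `Cn1nccc1-c1cnc(NCc2c(F)ccc3c2CCO3)c2cn[nH]c(=O)c12`, gives 2000 nM in this assay, lower still and also beyond the scatter. Compound 4, `O=C(Nc1cnc(NCc2c(F)ccc3c2CCO3)n2cnnc12)c1cccnc1`, is not yet measured; it differs from compound 1 in one place: ((pyridin-3-yl)carbonyl)amino in place of 2-oxopyrrolidin-1-yl on an aromatic carbon. Among the measured compounds shown here, no step between measured compounds covers this change, so the expectation rests on the two structures alone. The account expects a sizeable drop from compound 1 to compound 4 in this assay, estimated as a 13-fold lower number from compound 1 to compound 4 (1.11 log units; beyond the scatter), beyond the scatter. For compound 4 the estimated value in this assay is 50000 nM, expected to fall between 5000 nM and 300000 nM.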

Compound 4, solubility: 12000 nM
Estimate against measurement, compound 4: 4.2-fold (0.62 log units) above, within the range that was stated.
By their numbers in this assay, from the lowest: compounds 3 and 2 (each within the scatter of the next); then compound 4; then compound 1.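

The step shows that the group on this aromatic carbon of the shared core can, as a single change, move the number in this assay by a large amount: ((pyridin-3-yl)carbonyl)amino in place of 2-oxopyrrolidin-1-yl gives a 53-fold lower number from compound 1 to compound 4 (1.73 log units; beyond the scatter), with the rest of the structure held the same. The earlier compounds shown here carry different cores and could not show this for one position. No measurement at hand explains the step.

The compounds shown leave open whether the drop goes with the pyridine ring, the amide hydrogen or the larger group as a whole, for the entering group changes all of these at once. An acetylamino group, a benzoylamino group or a morpholine on this carbon would help to separate them, and a carboxylic acid would test another kind of group here.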